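This account rests on a few compounds, and the source may have more. Where it says the series, first, only, none or still open, it means among the compounds named here.

Measured in an in vitro functional assay on cells (Fibroblast) for agonist activity at Alpha-1D adrenergic receptor (Homo sapiens); a higher number here means that more compound is needed for the effect, a lower number that less compound is needed:
compound 1 `CCCn1ncnc1-c1ccccc1NCC1=NCCN1`: 251 nM
compound 2 `CC(C)n1ncnc1-c1ccccc1NCC1=NCCN1`: 3160 nM
compound 3 `Cc1ccc(-c2ccccc2NCC2=NCCN2)n1C`: < 100000 nM

Compound 3 stands apart from the other two in that its result is a limit of the assay and not a number, as shown by the limit of < 100000 nM in this assay, at which 1 of the 3 values shown sits. Among the compounds with values here, compound 1 and compound 2 both give numbers, and the one measured step between them, a 13-fold higher number from compound 1 to compound 2 (1.10 log units; beyond the scatter), concerns an alkyl group on an aromatic nitrogen.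

Compound 4 `Cn1cccc1-c1ccccc1NCC1=NCCN1` differs from compound 3 as follows: hydrogen in place of methyl on an aromatic carbon. Within the data shown here, the measured step of a 13-fold higher number from compound 1 to compound 2 (1.10 log units; beyond the scatter) sits at a different place and on a different kind of change, so it does not bear on the present step; no measured pair shows the effect of removing a methyl from an aromatic carbon. With compound 3 known only as a limit, no direction or size can be anchored for this step in this assay, and a weak value remains the plainest expectation.

Compound 4 is therefore estimated at 30000 nM in this assay, with a range from 3000 nM to 100000 nM. That estimate corresponds to an expected step that the limit leaves unreadable from compound 3 to compound 4.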

Compound 4, half-maximal effective concentration: 251 nM
Beside the measured number, compound 4's estimate is 120-fold (2.08 log units) above it; the measured number lies below the stated range.
By their numbers in this assay, from the lowest: compounds 1 and 4 (each within the scatter of the next); then compound 2.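

No step can be read from compound 3 to compound 4 in this assay, as compound 3 gives only a limit and not a number: the limit of < 100000 nM in this assay, at which 1 of the 4 values shown sits.

The compounds shown leave open how far, and in which direction, hydrogen in place of methyl on that aromatic carbon moves the number in this assay.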